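1H-1,2,3-triazol-5-yl for 1,2-oxazol-3-yl on a carbonyl carbon

The compounds below may be only part of what the source reports. "The series", "measured", "known", "first", "only" and "open" are said of these compounds alone.

Among the measured compounds shown here, in a physicochemical assay for solubility, read by nephelometry, measured as kinetic solubility, at pH 2.0 (a lower number here means a less soluble compound, a higher number a more soluble compound), compound 1 (`NCc1csc(NC(=O)c2ccon2)n1`) gives 50 ug/mL as the only true number so far. Compound 2 (`CN(C)Cc1csc(NC(=O)c2cc(C(C)(C)C)nn2Cc2ccccc2)n1`) reads > 100 ug/mL as a limit of the assay. Compound 3 (`NCc1csc(NC(=O)c2ccccc2)n1`) likewise reads > 100 ug/mL as a limit. Compound 4 (`NCc1csc(NC(=O)c2cnn[nH]2)n1`) carries 1H-1,2,3-triazol-5-yl in place of 1,2-oxazol-3-yl on a carbonyl carbon relative to compound 1. For the measured compounds named here, no measured step links compounds that differ in one place, and compound 1 at 50 ug/mL is the only anchor for the expectation. The expected step (a 1.2-fold higher number from compound 1 to compound 4 (0.08 log units; within the scatter)) is estimated to stay within the usual scatter, with no direction beyond it. For compound 4 the estimated solubility is 60 ug/mL with an expected range from 30 ug/mL to 100 ug/mL in this series.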

Compound 4, solubility: > 100 ug/mL
Compound 4: only a limit was reported (the forecaster's own chance of this, stated with the estimate: 25%); middle value at least 1.6-fold (0.22 log units) away from the limit.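

At the place on a carbonyl carbon, 1H-1,2,3-triazol-5-yl in place of 1,2-oxazol-3-yl gives, in this assay, an at least 2.0-fold higher number from compound 1 to compound 4 (0.30 log units; that floor lies within the scatter). Compound 4 reads > 100 ug/mL, which is a limit of the assay and not a number. This first step at this position therefore gives only a floor, and the reading offers little resolution here: the limit of > 100 ug/mL in this assay, at which 3 of the 4 values shown sit.

From the compounds shown here alone, how far the true value of compound 4 lies from this limit, and so whether the step exceeds the scatter, stays open. Going by these compounds, how a carboxylic acid or an amine on the carbonyl carbon would read in this assay also stays open.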